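Adding a 4-chlorophenyl group to compound 1

This account rests on a few compounds, and the source may have more. Where it says the series, first, only, none or still open, it means among the compounds named here.

Measured so far in an ADME assay on HeLa cells (Homo sapiens) for cytotoxicity; on this read-out lower numbers stand for higher toxicity in this test and higher numbers for lower toxicity in this test:
- Compound 1 `CCN(CC)CN1C(=O)/C(=N/NC(N)=S)c2cc(Cl)ccc21` gives > 100000 nM (a limit)
- Compound 2 `CCN(CC)CN1C(=O)/C(=N/NC(=S)Nc2ccccc2)c2ccccc21` gives 10800 nM

Compound 1 reads > 100000 nM, which is a limit of the assay and not a number. Compound 3 `CCN(CC)CN1C(=O)/C(=N/NC(=S)Nc2ccc(Cl)cc2)c2cc(Cl)ccc21` has not been measured yet. It differs from compound 1 in one place: 4-chlorophenyl in place of hydrogen on an amide-type nitrogen. Going by the values given here, no measured pair shows this change on its own, so its effect can only be expected. Since compound 2 gives 10800 nM as a true number, a large step toward lower numbers, beyond the scatter, is expected in this assay for compound 3. The estimated change is an at least 11-fold lower number from compound 1 to compound 3 (1.04 log units; beyond the scatter) in the direction of higher toxicity. For compound 3 the expected value is 9000 nM, with an estimated range from 2500 nM to 35000 nM.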

Compound 3, half-maximal cytotoxic concentration: 9400 nM
The estimate for compound 3 lay 1.0-fold (0.02 log units) below the measured number; the measured number falls inside the stated range.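

Putting 4-chlorophenyl in place of hydrogen on the amide-type nitrogen gives an at least 10-fold lower number from compound 1 to compound 3 (1.02 log units; beyond the scatter) in this assay. This is the first pair shown in which only this position differs, and it shows that the group on this nitrogen can by itself move the read-out toward higher toxicity in this test. The true size of the step remains unknown because compound 1 stands at a limit and not at a number: the limit of > 100000 nM in this assay, at which 1 of the 3 values shown sits.

The compounds shown do not tell whether the toxicity depends on the ring itself or on the chlorine it carries. They also leave open how a small chain such as methyl, or a ring such as 4-methoxyphenyl, would read on this same nitrogen.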